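The source may hold more compounds than are shown below. What is called first, only, known or untested is meant among the compounds shown, and "the series" means these compounds.

Compound 2 `CCCC(=O)N1CCN(c2nc(=O)c3cc(C(F)(F)F)cc([N+](=O)[O-])c3s2)CC1` holds the lower of the two numbers measured in a physicochemical assay for solubility, read by HPLC; a lower number here means a less soluble compound, a higher number a more soluble compound: compound 2 gives 2.46 ug/mL, while compound 1 `CSCC(=O)N1CCN(c2nc(=O)c3cc(C(F)(F)F)cc([N+](=O)[O-])c3s2)CC1` gives 15.2 ug/mL. For the measured compounds named here, the only step measured so far, a 6.2-fold lower number from compound 1 to compound 2 (0.79 log units; beyond the scatter), altered a different part of the chain than the change leading to compound 3 `CCC(=O)N1CCN(c2nc(=O)c3cc(C(F)(F)F)cc([N+](=O)[O-])c3s2)CC1`, which is hydrogen in place of methyl on a saturated chain carbon, two bonds along the chain from a carbonyl carbon. Going by the values given here, no measured step removes one carbon from this chain, so the expectation rests only loosely on the spread between compound 1 and compound 2. A small rise is expected, a 1.8-fold higher number from compound 2 to compound 3 (0.26 log units; within the scatter). Compound 3 is therefore estimated at 4.5 ug/mL in this assay, within a range from 1.5 ug/mL to 13 ug/mL.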

Compound 3, solubility: 3.29 ug/mL
Beside the measured number, compound 3's estimate is 1.4-fold (0.14 log units) above it; measured number inside the range.
By their numbers in this assay, from the lowest: compounds 2 and 3 (each within the scatter of the next); then compound 1.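

Trimming propylcarbonyl to propanoyl leaves the two compounds within the scatter (a 1.3-fold higher number from compound 2 to compound 3 (0.13 log units; within the scatter)), so in this assay this one-carbon difference does not separate them. Methyl in place of methylsulfanyl gives a step beyond the scatter (a 4.6-fold lower number from compound 1 to compound 3 (0.66 log units; beyond the scatter)), so compound 1 now stands apart from both of the analogues that lack the methylsulfanyl group. Nothing available explains either step. Still open, as far as these compounds go, is how an amine or a carboxylic acid on this chain, or a longer chain, would read in this assay.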